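The source may report more compounds than this note shows. Statements on the series, on what has been measured and on what is new or still open speak of the compounds shown alone.

Series notes, step from compound 3 to compound 4. In an assay on HEK293 cells for agonist activity at transient receptor potential cation channel subfamily M member 8 (Homo sapiens), read by fluorescence and calcium flux, with a stated time of 15 min (on this read-out lower numbers stand for an effect already at smaller amounts and higher numbers for an effect only at larger amounts of compound), compound 3 `C=CCN(Cc1cccs1)C(=O)COc1ccc(C)cc1` gives 20 nM, the lowest number among the three measured; compound 2 `Cc1ccc(OCC(=O)N(CCCO)Cc2cccs2)cc1` gives 3000 nM and compound 1 `Cc1ccc(OCC(=O)N(Cc2cccs2)C2CCCCC2)cc1` gives 40000 nM. Compound 4 `Cc1ccc(OCC(=O)N(Cc2cccs2)c2c(C)n[nH]c2C)cc1` is not yet measured; the change is 3,5-dimethyl-1H-pyrazol-4-yl in place of allyl on an amide-type nitrogen. Within the data shown here, two measured steps bear on it, both at the same amide-type nitrogen: a 2000-fold lower number from compound 1 to compound 3 (3.30 log units; beyond the scatter) and a 13-fold lower number from compound 1 to compound 2 (1.12 log units; beyond the scatter). Both show the allyl group far below the cyclohexyl ring, so a ring entering in place of the allyl is expected to move the number back up by a large step, a 500-fold higher number from compound 3 to compound 4 (2.70 log units; beyond the scatter). Compound 4 is therefore estimated at 10000 nM, within 1000 nM to 100000 nM.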

Compound 4, half-maximal effective concentration: 0.3 nM
Beside the measured number, compound 4's estimate is 33000-fold (4.52 log units) above it, and the stated range ends above it.
By their numbers in this assay, from the lowest: compound 4; then compound 3; then compound 2; then compound 1.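

In this assay, a ring on the amide-type nitrogen is not unfavourable in itself: 3,5-dimethyl-1H-pyrazol-4-yl outdoes the best open chain so far, allyl (a 67-fold lower number from compound 3 to compound 4 (1.82 log units; beyond the scatter)), and also 3-hydroxypropyl (a 10000-fold lower number from compound 2 to compound 4 (4.00 log units; beyond the scatter)). The widest gap lies between two rings at this position, cyclohexyl and the aromatic pyrazolyl (a 130000-fold lower number from compound 1 to compound 4 (5.12 log units; beyond the scatter)), so the kind of ring matters far more than the presence of one. Nothing measured here accounts for that gap.

Open, from the compounds shown here alone, is which part of the group carries the step: its two methyl groups, its ring nitrogens or the hydrogen on nitrogen. A plain phenyl ring or an unsubstituted pyrazolyl at this nitrogen would separate these.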